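Thiophen-2-yl for phenyl across two nucleoside cores

The compounds below may be only part of what the source reports. "The series", "measured", "known", "first", "only" and "open" are said of these compounds alone.

Compound 1 `COc1nc(N)nc2c1c(-c1ccccc1)cn2[C@@H]1O[C@H](CO)[C@@H](O)[C@H]1O` and compound 2 `COc1nc(N)nc2c1c(-c1cccs1)cn2[C@@H]1O[C@H](CO)[C@@H](O)[C@H]1O` share one core and differ as thiophen-2-yl in place of phenyl on an aromatic carbon. In an ADME assay on MRC5 cells (Homo sapiens), read by MTT assay, with a stated time of 72 h (on this read-out higher numbers stand for weaker inhibition and lower numbers for stronger inhibition), compound 1 gives only the limit of the assay, > 100000 nM. In this assay compound 2 gives only the limit as well, > 100000 nM. The step that the two limits leave unreadable from compound 1 to compound 2 is thus of unreadable size, all three measured values sitting at the same limit (the limit of > 100000 nM in this assay, at which 3 of the 3 values shown sit). Compound 3 `CNc1ncnc2c1c(-c1ccccc1)cn2[C@@H]1O[C@H](CO)[C@@H](O)[C@H]1O` rests on a second core; how the two cores differ is not broken down here. In this assay compound 3 gives only the limit, > 100000 nM. Compound 4 `CNc1ncnc2c1c(-c1cccs1)cn2[C@@H]1O[C@H](CO)[C@@H](O)[C@H]1O` is not yet measured and differs from compound 3 as thiophen-2-yl in place of phenyl on an aromatic carbon; this is the same kind of change as from compound 1 to compound 2, the place in one being told as bearing a group of 9 heavy atoms and in the other as bearing a 3,4-dihydroxy-5-(hydroxymethyl)oxolan-2-yl group. The step from compound 3 to compound 4 is expected to be a step that the limit leaves unreadable from compound 3 to compound 4, resting on the step that the two limits leave unreadable from compound 1 to compound 2. In this assay compound 4 is estimated at 150000 nM, within 60000 nM to 400000 nM.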

Compound 4, half-maximal inhibitory concentration: > 100000 nM
Compound 4 gave a limit, no number; the forecaster's own chance of this, stated with the estimate: 85%; the middle value does not contradict the limit.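

In this assay, going by these compounds alone, compound 4 gives only a limit, as compound 3 does, so no step from compound 3 to compound 4 can be read: the limit of > 100000 nM in this assay, at which 4 of the 4 values shown sit. The compounds shown leave open how thiophen-2-yl and phenyl compare on either core.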